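The source may report more compounds than this note shows. Statements on the series, on what has been measured and on what is new or still open speak of the compounds shown alone.

Compound 1 (`COc1ccc(CCCNCc2c(OC)cc(Oc3ccc(Nc4ccccc4)cc3)cc2OC)cc1`) gives 14600 nM in a functional assay on SW-620 cells (Homo sapiens) for inhibition, read by MTT assay, with a stated time of 72 h (on this read-out lower numbers stand for stronger inhibition and higher numbers for weaker inhibition), and compound 2 (`COc1cc(Oc2cccc(Nc3ccccc3)c2)cc(OC)c1CNCc1ccc(C)cc1`) gives 11800 nM there, while compound 3 (`COc1ccc([C@@H](C)NCc2c(OC)cc(Oc3cccc(Nc4ccccc4)c3)c(OC)c2OC)cc1`) gives 8250 nM there. Compound 2 thus sits within the scatter of both other compounds, which also lie within the scatter of each other. Compound 4 (`COc1cc(Oc2cccc(Nc3ccccc3)c2)cc(OC)c1CN(C)C`) differs from compound 2 by dimethylamino in place of (4-methylbenzyl)amino on a saturated chain carbon bound to an aromatic carbon in one place: dimethylamino in place of (4-methylbenzyl)amino on a saturated chain carbon bound to an aromatic carbon. Within the data shown here, no measured pair shows this change, so the expectation in this assay is only a moderate move toward weaker inhibition. The expected step is a 1.7-fold higher number from compound 2 to compound 4 (0.23 log units; within the scatter) in size. Compound 4 is estimated at 20000 nM with an expected range from 8000 nM to 50000 nM overall.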

Compound 4, half-maximal inhibitory concentration: > 20000 nM
Compound 4: only a limit was reported; the forecaster's own chance of this, stated with the estimate: 15%; the middle value sits exactly at the limit.
By their numbers in this assay, from the lowest: compounds 3, 2 and 1 (each within the scatter of the next). At a limit, above all of these: compound 4.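

In this assay, among these compounds, putting dimethylamino in place of (4-methylbenzyl)amino on a saturated chain carbon bound to an aromatic carbon gives the first single-place step here, an at least 1.6-fold higher number from compound 2 to compound 4 (0.22 log units; that floor lies within the scatter). Compound 4 has only a limit, so this step has a floor but no measured size: the limit of > 20000 nM in this assay, at which 1 of the 4 values shown sits.

The compounds shown leave open whether the change in activity, if any, follows from losing the aromatic ring or the amine hydrogen. Methylamino, which keeps that hydrogen without the ring, and methyl(4-methylbenzyl)amino, which keeps the ring without the hydrogen, would separate the two.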